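The source may report more compounds than this note shows. Statements on the series, on what has been measured and on what is new or still open speak of the compounds shown alone.

Measured so far in a physicochemical assay for lipophilicity; on this read-out lower numbers stand for lower lipophilicity and higher numbers for higher lipophilicity:
- compound 1 `COc1ccc(CN(CCN(C)C)c2ccccc2)cc1`: 3.9
- compound 2 `COc1ccc(CN(CCN(C)C)c2ccc(Cl)cn2)cc1`: 3.87

Within the data shown here, compound 2, at 3.87, cannot be told apart from compound 1, the only other measured compound. Among the measured compounds shown here, the one measured step is a number 0.03 log units lower from compound 1 to compound 2 (within the scatter).

Next in line is compound 3 `COc1ccc(CN(CCN(C)C)c2ccc(N)cn2)cc1`, with amino in place of chloro on an aromatic carbon. The same difference, cut one bond further out, reads 5-chloropyridin-2-yl to 5-aminopyridin-2-yl.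

The measured step bears on this only loosely. For the measured compounds named here, it exchanged a different pair of groups, and no measured compound carries amino, so it gives no direct guide to size. The expectation rests mainly on the structural change: the entering amino has hydrogen-bond donor and acceptor counts that the leaving chloro lacks. A move to a lower number in this assay, beyond the scatter, is therefore expected, though its size remains uncertain. The expected step is a number 1.17 log units lower from compound 2 to compound 3 (beyond the scatter). The estimate for compound 3 is 2.7, with a range of 2.1 to 3.3.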

Compound 3, partition coefficient: 2.56
The estimate for compound 3 lay 0.14 log units above the measured number, and the stated range covers the measured number.
By their numbers in this assay, from the lowest: compound 3; then compounds 2 and 1 (each within the scatter of the next).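

In this assay, among these compounds, the aromatic carbon para to a large group proves sensitive to what it carries: amino in place of chloro gives a number 1.31 log units lower from compound 2 to compound 3 (beyond the scatter), while the only earlier step stayed within the scatter. The 5-chloropyridin-2-yl group could not be told apart from phenyl on this read-out, but 5-aminopyridin-2-yl can, with a number 1.34 log units lower from compound 1 to compound 3 (beyond the scatter) on that exchange, so a ring nitrogen is not enough on its own to separate a compound from compound 1, since compound 2 carries one as well. The entering amino brings hydrogen-bond donor and acceptor counts that chloro lacks, but nothing available ties the step to those counts or to any other cause.

Among the compounds shown here, with only one amino compound in view, it remains open whether a step of this size belongs to amino itself or would also appear with hydroxyl, methylamino or acetamido at the same place. Also open, as far as these compounds go, is whether amino would give a comparable step on the phenyl ring of compound 1, which would show whether the result depends on the ring that carries it.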